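The source may report more compounds than this note shows. Statements on the series, on what has been measured and on what is new or still open speak of the compounds shown alone.

Measured compounds:
- compound 1, `Cc1ccccc1Cn1cc(COc2ccc3c(=O)ccoc3c2)nn1`: > 100000 nM
- compound 2, `O=c1ccoc2cc(OCc3cn(Cc4ccc(Cl)cc4Cl)nn3)ccc12`: 13300 nM
- compound 3, `O=c1ccoc2cc(OCc3cn(Cc4cccc([N+](=O)[O-])c4)nn3)ccc12`: 14100 nM

All three share one core and differ only in the aromatic group carried on a saturated chain carbon bound to an aromatic nitrogen. In a functional assay on QGY7701 cells (Homo sapiens) for cytotoxicity, read by MTT assay, with a stated time of 48 h (on this read-out lower numbers stand for stronger inhibition and higher numbers for weaker inhibition), compound 1 gives > 100000 nM, which is a limit of the assay rather than a number, so compound 1 stands only at the limit of > 100000 nM in this assay, at which 1 of the 3 values shown sits, and cannot be placed more precisely. Compound 2 gives 13300 nM and compound 3 gives 14100 nM; the two lie within the scatter of each other, as shown by a 1.1-fold higher number from compound 2 to compound 3 (0.03 log units; within the scatter).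

Compound 4, `N#Cc1cccc(Cn2cc(COc3ccc4c(=O)ccoc4c3)nn2)c1`, is not yet measured. It differs from compound 1 by 3-cyanophenyl in place of 2-methylphenyl on a saturated chain carbon bound to an aromatic nitrogen. Going by the values given here, the steps that bear on this change are an at least 7.5-fold lower number from compound 1 to compound 2 (0.87 log units; beyond the scatter) and an at least 7.0-fold lower number from compound 1 to compound 3 (0.85 log units; beyond the scatter): in both cases swapping the 2-methylphenyl for another substituted phenyl gave a lower number beyond the scatter. For compound 4 a step of similar direction and size is therefore expected, roughly an at least 6.6-fold lower number from compound 1 to compound 4 (0.82 log units; beyond the scatter). Compound 4 is estimated to reach 15000 nM in this assay, within a range of 5000 nM to 60000 nM.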

Compound 4, half-maximal inhibitory concentration: 24400 nM
For compound 4 the middle estimate is 1.6-fold (0.21 log units) below the measured one, and the stated range covers the measured number.
By their numbers in this assay, from the lowest: compounds 2, 3 and 4 (each within the scatter of the next). At a limit, above all of these: compound 1.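

Compound 1 is held only at a limit of the assay, not at a number: the limit of > 100000 nM in this assay, at which 1 of the 4 values shown sits. Even so, a third replacement of the 2-methylphenyl, this time by 3-cyanophenyl, points the same way in this assay, with an at least 4.0-fold lower number from compound 1 to compound 4 (0.61 log units; beyond the scatter), so every replacement shown so far at this position has gone in one direction. The three replacements themselves cannot be told apart, with a 1.7-fold higher number from compound 3 to compound 4 (0.24 log units; within the scatter) and a 1.8-fold higher number from compound 2 to compound 4 (0.26 log units; within the scatter), so changing nitro to cyano on an aromatic carbon makes no difference that can be read here.

Still open, from the compounds shown here alone, is whether the 2-methylphenyl is unusual or the replacements are what matter, a question that a plain unsubstituted phenyl could help settle. Going by these compounds, it is also open whether an amine or a carboxylic acid on the phenyl ring would move the number beyond this narrow band.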